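This account rests on a few compounds, and the source may have more. Where it says the series, first, only, none or still open, it means among the compounds named here.

Working notes on the series. Three compounds sharing one core carry different groups on an aromatic carbon of the fused ring system: compound 1 `O=C(CCCCC1CCSS1)NCc1cn(CCCOc2ccc3ccc(=O)oc3c2)nn1` with hydrogen there, compound 2 `Cc1cc(=O)oc2cc(OCCCn3cc(CNC(=O)CCCCC4CCSS4)nn3)ccc12` with methyl, and compound 3 `CCOC(=O)c1cc2ccc(OCCCn3cc(CNC(=O)CCCCC4CCSS4)nn3)cc2oc1=O` with ethoxycarbonyl. In a functional assay on PC-12 cells (Rattus norvegicus) for cytotoxicity, read by MTT assay, with stated times of 3 h and 2 h, tested at 5 uM (a lower number here means a weaker effect, a higher number a stronger effect of the compound at the concentration tested), compound 1 gives 39.2%, compound 2 gives 64.6% and compound 3 gives 32.4%. Compound 3 holds the lowest of the three numbers; its gap to compound 1 lies within the scatter, while compound 2 stands beyond the scatter above it.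

The two measured steps start from compound 1: a number 25.4 percentage points higher from compound 1 to compound 2 (beyond the scatter), and a number 6.8 percentage points lower from compound 1 to compound 3 (within the scatter). Both replace hydrogen at the same place, so neither reproduces the move to compound 4 `O=C(CCCCC1CCSS1)NCc1cn(CCCOc2ccc3cc(-c4ccccc4)c(=O)oc3c2)nn1`, in which the change is phenyl in place of ethoxycarbonyl on an aromatic carbon. What the steps show is that the aromatic carbon tolerates substitution without loss and that a small carbon-only group raised the number by a modest amount, whereas ethoxycarbonyl left it unchanged within the scatter. A carbon-only phenyl group thus seems more likely to move the number upward than downward, but the evidence is indirect and the size uncertain.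

For compound 4 the expected value in this assay is 45%, within a range of 25% to 68%. That estimate means an expected step of a number 12.6 percentage points higher from compound 3 to compound 4 (beyond the scatter), a modest rise that may not clear the scatter.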

Compound 4, a percentage reported as activity, at one concentration (the size of the read-out at that concentration, not a potency): 29.8%
Beside the measured number, compound 4's estimate is 15.2 percentage points above it; measured number inside the range.
By their numbers in this assay, from the lowest: compounds 4, 3 and 1 (each within the scatter of the next); then compound 2.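

In this assay phenyl in place of ethoxycarbonyl gives a number 2.6 percentage points lower from compound 3 to compound 4 (within the scatter) and phenyl in place of hydrogen gives a number 9.4 percentage points lower from compound 1 to compound 4 (within the scatter) so hydrogen, ethoxycarbonyl and phenyl cannot be told apart on this aromatic carbon, two atoms from the ring oxygen, even though phenyl brings a six-membered aromatic ring of carbon only. A carbon-only group therefore does not raise the number by that fact alone: of the substituted compounds, only compound 2 with methyl stands beyond the scatter from compound 1, with a number 25.4 percentage points higher from compound 1 to compound 2 (beyond the scatter) and compound 4 goes against any pattern that would extend this rise to all carbon-only groups. The data shown offer no explanation for why methyl and phenyl part in this way.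

As far as these compounds go, it remains open whether a group carrying a hydrogen-bond donor, such as an amine or a carboxylic acid, would separate from hydrogen on this aromatic carbon. Also open, from the compounds shown here alone, is whether an ethyl or a longer alkyl chain would follow methyl or stay with phenyl, which would show whether the rise seen with compound 2 extends beyond that single group.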